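The source may report more compounds than this note shows. Statements on the series, on what has been measured and on what is new or still open speak of the compounds shown alone.

Measured compounds:
Compound 1 `Cc1ccc(NC(=O)C(=O)NC(c2nc(C)c(CO)s2)C2CCCCN2)cc1F` — > 88000 nM
Compound 2 `CC(=O)c1ccc(NC(=O)C(=O)NC(c2nc(C)c(CO)s2)C2CCCCN2)cc1` — > 86000 nM
Compound 3 `Cc1nc(C(NC(=O)C(=O)Nc2ccc(F)cc2)C2CCCCN2)sc1CO` — > 90000 nM

In an ADME assay on TZM-b1 cells (Homo sapiens) for cytotoxicity, read by XTT assay, with a stated time of 3 days (on this read-out higher numbers stand for lower toxicity in this test and lower numbers for higher toxicity in this test), compound 1 reports only a limit of the assay, not a number. Compound 2 likewise gives a limit in this assay. Compound 3 also gives a limit in this assay. Compound 2 therefore stands at a limit, as do the two other values shown (the limit of > 86000 nM in this assay, at which 1 of the 3 values shown sits, (the limit of > 88000 nM in this assay, at which 1 of the 3 values shown sits), (the limit of > 90000 nM in this assay, at which 1 of the 3 values shown sits)).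

Compound 4 `CC(=O)c1ccc(NC(=O)C(=O)NC(c2nc(C)c(CCO)s2)C2CCCCN2)cc1` differs from compound 2 by hydroxymethyl in place of hydroxy on a saturated chain carbon bound to an aromatic carbon. For the measured compounds named here, the steps that bear on it, a step that the two limits leave unreadable from compound 1 to compound 2 and a step that the two limits leave unreadable from compound 2 to compound 3, are unreadable between limits, so no readable change is expected in this assay. Compound 4 is estimated at 100000 nM (40000 nM to 300000 nM), most likely again a limit.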

Compound 4, half-maximal cytotoxic concentration: > 77300 nM
Compound 4: a limit, no number (the forecaster's own chance of this, stated with the estimate: 85%); the middle value is on the limit's open side.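

For the compounds shown here, compound 2 and compound 4 both give only limits in this assay, and no step between them can be read. The compounds shown leave open whether 2-hydroxyethyl in place of hydroxymethyl changes this read-out at all.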